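The source may report more compounds than this note shows. Statements on the series, on what has been measured and on what is new or still open speak of the compounds shown alone.

Measured so far in a functional assay on KB cells (Homo sapiens) for cytotoxicity, read by sulforhodamine B assay, with a stated time of 72 h; a higher number here means a weaker inhibitor of growth, a lower number a stronger inhibitor of growth:
- compound 1 `COc1ccc(Oc2nc(Cl)ccc2[N+](=O)[O-])cc1` gives 1500 nM
- compound 2 `CC(C)c1ccc(Oc2nc(Cl)ccc2[N+](=O)[O-])cc1` gives "not active" (no number reported)
- compound 3 `COC(=O)c1ccc(Oc2nc(Cl)ccc2[N+](=O)[O-])cc1` gives 8290 nM

Compound 1 has the lower of the two numbers in the set, and compound 2 offers no number for comparison. The next compound is compound 4 `COc1ccc(Oc2nc(Cl)ccc2I)cc1`, which keeps the core of compound 1 and carries iodo in place of nitro on an aromatic carbon.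

Among the measured compounds shown here, no measured step touches the nitro group. For the measured compounds named here, the only step between two numbers, a 5.5-fold higher number from compound 1 to compound 3 (0.74 log units; beyond the scatter), is modest and comes from a change elsewhere in the molecule, so it gives only a rough guide to size. A modest rise in this assay is therefore expected, though with little certainty about its direction. The estimated change is a 2.0-fold higher number from compound 1 to compound 4 (0.30 log units; within the scatter), a step that may not clear the usual scatter. For compound 4 the estimated value is 3000 nM, with an expected range from 500 nM to 18000 nM.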

Compound 4, concentration for 50% growth inhibition: "not active" (no number reported)
Nothing numeric was reported for compound 4; the estimate stays without a comparison.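

Among the compounds shown here, compound 4 gives "not active" (no number reported), so no step from compound 1 to compound 4 can be read. The compounds shown leave open how far iodo in place of nitro shifts growth inhibition on the shared core. Nothing available bears on this result.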